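The compounds below may be only part of what the source reports. "The series", "measured", "known", "first", "only" and "open" are said of these compounds alone.

Measured so far in an assay on isolated protein for binding affinity to Oxytocin receptor (Homo sapiens); a lower number here means a stronger inhibitor, a higher number a weaker inhibitor:
Compound 1, `CNC(=O)c1ccc([C@H](C(=O)NC(C)C)N2C(=O)[C@@H](C3Cc4ccccc4C3)NC(=O)[C@H]2CC(C)C)o1`: 39.8 nM
Compound 2, `Cc1nc([C@H](C(=O)NC(C)C)N2C(=O)[C@@H](C3Cc4ccccc4C3)NC(=O)[C@H]2CC(C)C)co1`: 1.26 nM

Compound 2 stands lowest of the two numbers. Within the data shown here, the only measured step, a 32-fold lower number from compound 1 to compound 2 (1.50 log units; beyond the scatter), changed the aromatic ring and says nothing about the amide end of the molecule.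

Compound 3, `Cc1nc([C@H](C(=O)N(C)CCO)N2C(=O)[C@@H](C3Cc4ccccc4C3)NC(=O)[C@H]2CC(C)C)co1`, differs from compound 2 by (2-hydroxyethyl)(methyl)amino in place of isopropylamino on a carbonyl carbon. Among the measured compounds shown here, no measured step touches this place, so the two measured compounds give no direct guide. The step of a 1.6-fold higher number from compound 2 to compound 3 (0.20 log units; within the scatter) is therefore expected to stay within the usual scatter, with a wide range to reflect the missing precedent. Compound 3 is estimated at 2 nM, between 0.5 nM and 8 nM.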

Compound 3, inhibition constant in the Oxytocin receptor assay: 1.26 nM
Estimate against measurement, compound 3: 1.6-fold (0.20 log units) above; measured number inside the range.
By their numbers in the Oxytocin receptor assay, from the lowest: compounds 2 and 3 (each within the scatter of the next); then compound 1.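

In the Oxytocin receptor assay, putting (2-hydroxyethyl)(methyl)amino in place of isopropylamino on a carbonyl carbon gives no change at the digits printed from compound 2 to compound 3 (within the scatter), so this place accepts the change without a readable loss of binding. In the Oxytocin receptor assay compound 2 gives 1.26 nM and compound 3 gives 1.26 nM at the digits printed. Among these compounds, the earlier step changed only the aromatic ring, which makes this the first reading at this place. In a physicochemical assay for solubility (on this read-out lower numbers stand for lower solubility and higher numbers for higher solubility), compound 2 stands at > 240 ug/mL which is a limit of the assay and not a number. In the physicochemical assay compound 3 stands at > 220 ug/mL which is likewise a limit of the assay and not a number. Their step cannot be read.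

As far as these compounds go, whether a longer chain ending in an amine would be accepted on this carbonyl carbon stays open.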